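Ester series: from compound 3 to compound 4

The compounds below may be only part of what the source reports. "The series", "measured", "known", "first", "only" and "open" are said of these compounds alone.

In an ADME assay on HepG2 2.2.15 cells (Homo sapiens) for cytotoxicity (a higher number here means that more compound is tolerated, a lower number that less compound is tolerated), three esters of the shared core have measured numbers. Compound 1 (`CC(=O)OCC(=O)OCCc1c(-c2ccccc2Cl)c2cc(Cl)ccc2[nH]c1=O`) gives 100000 nM, compound 2 (`O=C(OCCc1c(-c2ccccc2Cl)c2cc(Cl)ccc2[nH]c1=O)C1CCCC1`) gives 46000 nM, and compound 3 (`O=C(CCC1CCCCC1)OCCc1c(-c2ccccc2Cl)c2cc(Cl)ccc2[nH]c1=O`) gives 160000 nM. Compound 3 sits at the upper end of this short range, level within the scatter with compound 1: a 1.6-fold higher number from compound 1 to compound 3 (0.20 log units; within the scatter). The gap to the remaining ester is larger: a 3.5-fold higher number from compound 2 to compound 3 (0.54 log units; beyond the scatter).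

Compound 4 (`O=C(OCCc1c(-c2ccccc2Cl)c2cc(Cl)ccc2[nH]c1=O)c1cccs1`) has thiophen-2-yl in place of 2-cyclohexylethyl on a carbonyl carbon. Among the compounds with values here, no measured compound carries thiophen-2-yl, so the evidence is indirect. The nearest comparison is compound 2, which also has a ring directly on that carbonyl carbon, and its step of a 3.5-fold higher number from compound 2 to compound 3 (0.54 log units; beyond the scatter) is modest. The other step at this carbonyl carbon, a 2.2-fold lower number from compound 1 to compound 2 (0.34 log units; beyond the scatter), is also modest, so the measured esters span only a narrow range. A modest fall toward compound 2 is therefore expected, with the estimated step being a 2.3-fold lower number from compound 3 to compound 4 (0.36 log units; beyond the scatter). For compound 4 the estimated value is 70000 nM, with an expected range of 30000 nM to 160000 nM.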

Compound 4, half-maximal cytotoxic concentration: > 1700000 nM
Compound 4: a limit, no number; the forecaster's own chance of this, stated with the estimate: 10%; at least 24-fold (1.38 log units) between middle value and limit.
By their numbers in this assay, from the lowest: compound 2; then compounds 1 and 3 (each within the scatter of the next). At a limit, above all of these: compound 4.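

In this assay compound 4 gives no number, only a limit: the limit of > 1700000 nM in this assay, at which 1 of the 4 values shown sits.

All three steps to it are large: an at least 10-fold higher number from compound 3 to compound 4 (1.02 log units; beyond the scatter), an at least 36-fold higher number from compound 2 to compound 4 (1.56 log units; beyond the scatter), and an at least 17-fold higher number from compound 1 to compound 4 (1.23 log units; beyond the scatter). Within the data shown here, the earlier steps at this carbonyl carbon, among acetoxymethyl, cyclopentyl and 2-cyclohexylethyl, were no more than modest, so thiophen-2-yl is the first group to shift the number by a large amount from this place, and the position proves far less flat than those three esters suggested.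

Still open, as far as these compounds go, is whether the shift goes with an aromatic ring on the carbonyl carbon as such or with the sulfur of thiophen-2-yl, a question that a phenyl or furan-2-yl ester on the shared core would address. From the compounds shown here alone, the true value of compound 4 also remains unknown, so each of its steps is a minimum size, and how far thiophen-2-yl really separates from the other three groups cannot be read.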